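The source may report more compounds than this note shows. Statements on the series, on what has been measured and on what is new or still open speak of the compounds shown alone.

Compound 1 `Cc1ccc(C(CCN(C)C)NC(=O)CCc2ccccc2)cc1` is tested in a functional assay on NIH3T3 cells for agonist activity at Urotensin-2 receptor (Homo sapiens), with a stated time of 5 days (a higher number here means that more compound is needed for the effect, a lower number that less compound is needed), where compound 1 gives 4570 nM. Among the three compounds measured, this is the highest number. Its nearest neighbour is compound 3 `Cc1ccc(C(CCN(C)C)NC(=O)C#Cc2ccccc2)cc1`, which in this assay gives 3090 nM; the step of a 1.5-fold lower number from compound 1 to compound 3 (0.17 log units; within the scatter) lies within the scatter. Furthest away is compound 2 `CN(C)CCC(NC(=O)/C=C/c1ccc(C(F)(F)F)cc1)c1ccc2ccccc2c1`, which in this assay gives 135 nM, a far lower number, but compound 2 differs from compound 1 in several places at once, so no single step connects them.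

Compound 4 `COc1ccc(CCC(=O)NC(CCN(C)C)c2ccc(C)cc2)cc1` differs from compound 1 in one place: methoxy in place of hydrogen on an aromatic carbon. Going by the values given here, the only measured step in the set, from compound 1 to compound 3, alters the carbonyl side and not the aromatic ring, so it does not bear on this change; no measured step touches the place where the methoxy enters. With nothing to point either way, a step of a 1.5-fold lower number from compound 1 to compound 4 (0.18 log units; within the scatter) is expected, within the scatter or a little beyond it. Compound 4 is therefore estimated at 3000 nM, with a range from 1000 nM to 9000 nM.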

Compound 4, half-maximal effective concentration: 5370 nM
Compound 4: the middle estimate sits 1.8-fold (0.25 log units) below what was measured; measured number inside the range.
By their numbers in this assay, from the lowest: compound 2; then compounds 3, 1 and 4 (each within the scatter of the next).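

In this assay, the step from phenyl to 4-methoxyphenyl gives a 1.2-fold higher number from compound 1 to compound 4 (0.07 log units; within the scatter). Going by these compounds alone, this is the first measured step at this place, an aromatic carbon para to a large group, and it shows that the methoxy can enter there while the two numbers stay within the scatter of each other. No experimental information shown here speaks to the reason for this result.

Going by these compounds, whether an amine or a carboxylic acid at the same place would also stay within the scatter remains open. Also open, on these data alone, is whether methoxy would give a similar result on the phenyl ring of compound 3, where 2-phenylethynyl replaces phenethyl on the carbonyl carbon.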